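This account rests on a few compounds, and the source may have more. Where it says the series, first, only, none or still open, it means among the compounds named here.

Working notes on the series. In an ADME assay on HEK293 cells (Homo sapiens) for cytotoxicity, read by ATP content, with a stated time of 6 h (a higher number here means that more compound is tolerated, a lower number that less compound is tolerated), compound 1 (`CCCCNc1nc(N)nc2ccn(Cc3ccccc3)c12`) gives > 24000 nM, which is a limit of the assay and not a number. Compound 2 (`CCCCNc1nc(N)nc2ccn(CC(=O)NC)c12`) gives > 24000 nM, also only a limit. Compound 2 therefore has no measured number, and its position is known only from that limit.

Compound 3 (`CCCCNc1nc(N)nc2ccn(CC=C(C)C)c12`) carries 2-methylprop-1-en-1-yl in place of methylcarbamoyl on a saturated chain carbon bound to an aromatic nitrogen. For the measured compounds named here, the same place was changed in the only measured step, a step that the two limits leave unreadable from compound 1 to compound 2. The wider record is the limit of > 24000 nM in this assay, at which 2 of the 2 values shown sit. Neither compound offers a size to carry over, so the expectation rests on the shared limit alone.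

Going by the values given here, with a step that the two limits leave unreadable from compound 1 to compound 2 as the sole guide, no step beyond the scatter is expected in this assay, in either direction, and another report at the limit is the likeliest outcome. The estimated change is a step that the limit leaves unreadable from compound 2 to compound 3. For compound 3 the estimate is 30000 nM, with an expected range of 14000 nM to 60000 nM.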

Compound 3, half-maximal cytotoxic concentration: > 24000 nM
Compound 3: a limit, no number; the forecaster's own chance of this, stated with the estimate: 80%; the middle value does not contradict the limit.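

No step among compound 1, compound 2 and compound 3 can be read, since each gives only a limit of the assay and not a number: the limit of > 24000 nM in this assay, at which 3 of the 3 values shown sit.

The compounds shown leave open where the half-maximal cytotoxic concentration of each lies, and whether any of the three groups at this place differs from the others.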